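This account rests on a few compounds, and the source may have more. Where it says the series, first, only, none or still open, it means among the compounds named here.

In a functional assay on colon cells (Homo sapiens) for antiproliferative activity (a lower number here means a stronger inhibitor of growth, a higher number a weaker inhibitor of growth), compound 1 `Cc1cn2c(/C=N/NC(=N)N)c(-c3ccncc3)nc2s1` gives 34700 nM, compound 2 `Cc1sc2nc(-c3ccncc3)c(/C=N/NC(=N)N)n2c1C` gives 79400 nM and compound 3 `N=C(N)N/N=C/c1c(-c2cc([N+](=O)[O-])c(Cl)cc2Cl)nc2sc(Cl)cn12` gives 50100 nM. Compound 1 and compound 3 lie within the scatter of each other, while compound 2 has the highest number of the three by value alone.

The unmeasured compound 4 `N=C(N)N/N=C/c1c(-c2ccncc2)nc2sc(Cl)cn12` differs from compound 1 at one place: chloro in place of methyl on an aromatic carbon. This puts chloro in place of methyl on an aromatic carbon, next to the ring sulfur.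

Among the compounds with values here, no measured step makes this exact swap. The closest is a 2.3-fold higher number from compound 1 to compound 2 (0.36 log units; beyond the scatter), a modest change from methyl in place of hydrogen on an aromatic carbon, and it bears on the new change only loosely. Compound 3 offers a second clue, since it carries chloro on the same carbon, though with a different ring on the core, and it gives 50100 nM.

On this evidence, no change beyond the scatter is expected in this assay, and the estimated result is a 1.2-fold higher number from compound 1 to compound 4 (0.06 log units; within the scatter). Compound 4 is expected at about 40000 nM, within an estimated range of 20000 nM to 80000 nM.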

Compound 4, concentration for total growth inhibition: 27500 nM
The estimate for compound 4 lay 1.5-fold (0.16 log units) above the measured number; the range from low to high includes it.
By their numbers in this assay, from the lowest: compounds 4, 1, 3 and 2 (each within the scatter of the next, the first and the last beyond it).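

Within the data shown here, the pair of compound 1 and compound 4 isolates this swap for the first time, since compound 3 also carries chloro on this carbon but differs from compound 1 elsewhere as well. In this assay the result is a 1.3-fold lower number from compound 1 to compound 4 (0.10 log units; within the scatter) and so, on the carbon next to the ring sulfur, chloro and methyl cannot be told apart in this read-out. Nothing available explains why the two groups give such similar numbers.

From the compounds shown here alone, only methyl and chloro are seen on this carbon with the rest of compound 1 unchanged, so the effect of hydrogen alone here remains unknown. Going by these compounds, it is also open whether an amine, a carboxylic acid or a longer chain at this position would leave the number unchanged or shift it beyond the scatter.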